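This account rests on a few compounds, and the source may have more. Where it says the series, first, only, none or still open, it means among the compounds named here.

In a functional assay on DU-145 cells (Homo sapiens) for antiproliferative activity, read by WST assay, with a stated time of 3 days (on this read-out higher numbers stand for weaker inhibition and lower numbers for stronger inhibition), compound 1 (`CCCOc1c(-c2cc(OC)c(OC)c(OC)c2)oc2ccccc2c1=O`) gives 2800 nM. Compound 2 (`CCCCCCOc1c(-c2cc(OC)c(OC)c(OC)c2)oc2ccccc2c1=O`) carries a longer chain on the same oxygen and gives > 50000 nM, which is a limit of the assay and not a number. Compound 2 therefore stands at the limit of > 50000 nM in this assay, at which 1 of the 2 values shown sits.

Compound 3 (`CCCCCCCOc1c(-c2cc(OC)c(OC)c(OC)c2)oc2ccccc2c1=O`) differs from compound 2 by a single small change, methyl in place of hydrogen on a saturated chain carbon, six bonds along the chain from an oxygen on an aromatic ring.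

Among the compounds with values here, only one measured step bears on this change. It also lengthens the chain, and it runs an at least 17-fold higher number from compound 1 to compound 2 (1.25 log units; beyond the scatter), a large move towards weaker inhibition. The new change adds less than that propyl did, but it points the same way, so compound 3 is expected to stay as weak as compound 2 in this assay, with no recovery of activity. The expected size is a number no higher from compound 2 to compound 3 (the limit leaves the size open), which would not stand out from the scatter. For compound 3 the estimated value is 50000 nM, with an expected range of 25000 nM to 100000 nM.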

Compound 3, half-maximal inhibitory concentration: > 50000 nM
Compound 3: only a limit was reported; the forecaster's own chance of this, stated with the estimate: 80%; the middle value sits exactly at the limit.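

The longer chain again costs activity, with an at least 17-fold higher number from compound 1 to compound 3 (1.25 log units; beyond the scatter), so the large loss now holds for two long chains on that oxygen rather than one, and adding a methyl at the far end brings no activity back. The effect of that methyl cannot be read, because the step between the two long-chain compounds runs from one limit to another: the limit of > 50000 nM in this assay, at which 2 of the 3 values shown sit.

The compounds shown leave open how activity changes between the propyl chain and the longer chains, and so whether a butyl or pentyl chain on the same oxygen would keep any of it. As far as these compounds go, it also remains open whether a chain ending in an amine or a carboxylic acid would behave like these plain carbon chains.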